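From Thiazolyl to Diethylsulfamoyl: Expected Effect on Cytotoxicity

This account rests on a few compounds, and the source may have more. Where it says the series, first, only, none or still open, it means among the compounds named here.

Of the compounds shown here, three sharing one core have been measured in an ADME assay on PC-3 cells (Homo sapiens) for cytotoxicity, read by WST assay, tested at 100 uM; on this read-out higher numbers stand for more inhibition at the one concentration tested (going by the name of the read-out) and lower numbers for less inhibition. Compound 1 `Cc1cccc(C(=O)N2CCCC(C(=O)Nc3ccc(Cl)cc3)C2)c1` gives 0%, and compound 2 `COC(=O)c1cccc(C(=O)N2CCCC(C(=O)Nc3ccc(Cl)cc3)C2)c1` gives 0%; the step of no change at the digits printed from compound 1 to compound 2 (within the scatter) shows that exchanging one small group for another left the read-out flat. Compound 3 `O=C(Nc1ccc(Cl)cc1)C1CCCN(C(=O)c2cccc(-c3nccs3)c2)C1` gives 32% in this assay and stands highest of the three, with a number 32 percentage points higher from compound 1 to compound 3 (beyond the scatter) and a number 32 percentage points higher from compound 2 to compound 3 (beyond the scatter) both large and beyond the scatter.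

Compound 4 `CCN(CC)S(=O)(=O)c1cccc(C(=O)N2CCCC(C(=O)Nc3ccc(Cl)cc3)C2)c1` has not yet been measured. It differs from compound 3 in one place: diethylsulfamoyl in place of 1,3-thiazol-2-yl on an aromatic carbon.

Both large steps that bear on this change point the same way: the 1,3-thiazol-2-yl group that enters in a number 32 percentage points higher from compound 1 to compound 3 (beyond the scatter) and a number 32 percentage points higher from compound 2 to compound 3 (beyond the scatter) is the only feature so far linked to a read-out above zero, and it now leaves. Within the data shown here, the diethylsulfamoyl group that enters has no precedent among the measured compounds, so its own contribution is unknown. The expected step is therefore a fall, a number 24 percentage points lower from compound 3 to compound 4 (beyond the scatter), back toward the level of compound 1 and compound 2. Compound 4 is expected to give 8% in this assay, within a range from 0% to 30%.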

Compound 4, a percentage reported as inhibition, at one concentration (the size of the read-out at that concentration, not a potency): 0%
For compound 4 the middle estimate is 8 percentage points above the measured one; the range from low to high includes it.
By their numbers in this assay, from the lowest: compounds 1, 2 and 4 (each within the scatter of the next); then compound 3.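

In this assay, putting diethylsulfamoyl in place of 1,3-thiazol-2-yl on this aromatic carbon, meta to a large group, gives a clear loss of the read-out (a number 32 percentage points lower from compound 3 to compound 4 (beyond the scatter)), so the effect seen with compound 3 does not carry over to this group, which has no ring. The new group also reads the same as the two earlier small groups (no change at the digits printed from compound 2 to compound 4 (within the scatter); no change at the digits printed from compound 1 to compound 4 (within the scatter)), so methyl, methoxycarbonyl and diethylsulfamoyl cannot be told apart here, and among these four compounds only the 1,3-thiazol-2-yl group in compound 3 stands apart. Nothing at hand explains why the read-out follows this one group.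

The compounds shown leave open whether the step depends on the thiazole itself or on any aromatic ring at this place, which an oxazol-2-yl, a thiophen-2-yl, a pyridyl or a plain phenyl group would help to settle. They also leave open whether a sulfamoyl group with smaller substituents, such as dimethylsulfamoyl or the unsubstituted sulfonamide, would read differently from diethylsulfamoyl.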